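The compounds below may be only part of what the source reports. "The series", "measured", "known", "first", "only" and "open" are said of these compounds alone.

Working notes on the series, read in an ADME assay on HepG2 cells (Homo sapiens) for cytotoxicity, read by MTT assay, with a stated time of 48 h; on this read-out higher numbers stand for lower toxicity in this test and lower numbers for higher toxicity in this test. Compound 1 (`CC(=O)OC[C@H]1O[C@H](OC[C@@H](Cn2cc(CN(c3nc(-c4ccc([N+](=O)[O-])cc4)no3)C3CCCCC3)nn2)OC(C)=O)C=C[C@@H]1OC(C)=O`) reads > 200 ug/mL, which is a limit of the assay and not a number. For the measured compounds named here, compound 2 (`CC(=O)OC[C@H]1O[C@H](OC[C@@H](Cn2cc(CN(c3nc(-c4cccc(C)c4)no3)C3CCCCC3)nn2)OC(C)=O)C=C[C@@H]1OC(C)=O`) gives 39.2 ug/mL, the only true number so far. Going by the values given here, the one measured step, an at least 5.1-fold lower number from compound 1 to compound 2 (0.70 log units; beyond the scatter), lies beyond the scatter. Going by these compounds, for compound 1 the full size of that step stays open because of the limit of > 200 ug/mL in this assay, at which 1 of the 2 values shown sits.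

Compound 3 (`CC(=O)OC[C@H]1O[C@H](OC[C@@H](Cn2cc(CN(c3nc(-c4ccc(C(F)(F)F)cc4)no3)C3CCCCC3)nn2)OC(C)=O)C=C[C@@H]1OC(C)=O`) differs from compound 2 in one place, with 4-(trifluoromethyl)phenyl in place of 3-methylphenyl on an aromatic carbon. Among the compounds with values here, only the step above bears on this change, since it concerns the same aromatic substituent, and a single pair sets no pattern. Going by an at least 5.1-fold lower number from compound 1 to compound 2 (0.70 log units; beyond the scatter), leaving 3-methylphenyl is expected to raise the number in this assay, though probably by less than that step and perhaps by little more than the scatter. The expected change is a 2.0-fold higher number from compound 2 to compound 3 (0.31 log units; beyond the scatter). Compound 3 is estimated at 80 ug/mL, with an expected range from 30 ug/mL to 200 ug/mL.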

Compound 3, half-maximal cytotoxic concentration: 81.4 ug/mL
Estimate against measurement, compound 3: 1.0-fold (0.01 log units) below; low and high end bracket the measured number.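

For the compounds shown here, at this position, on an aromatic carbon between two ring nitrogen atoms, this assay now separates two true numbers for the first time: a 2.1-fold higher number from compound 2 to compound 3 (0.32 log units; beyond the scatter). The change to trifluoromethyl in place of nitro also lies beyond the scatter, an at least 2.4-fold lower number from compound 1 to compound 3 (0.39 log units; beyond the scatter), so the 4-nitrophenyl group and the 4-(trifluoromethyl)phenyl group do not read alike here, and the three aromatic groups now fall in one order, with 3-methylphenyl lowest, 4-(trifluoromethyl)phenyl in the middle and 4-nitrophenyl highest. The full size of that last step stays open because compound 1 stands at a limit of the assay, not at a number: the limit of > 200 ug/mL in this assay, at which 1 of the 3 values shown sits.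

The step to 4-(trifluoromethyl)phenyl changes both the substituent and where it sits on the phenyl ring, so the compounds shown do not tell these two apart, and 4-methylphenyl or unsubstituted phenyl would be needed to separate them. Going by these compounds, how an amine or a carboxylic acid on the phenyl ring would read in this assay also remains open, as does whether this order holds with any group other than cyclohexyl on the shared core.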